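Half-life of compound 3 in mouse liver microsomes

A few compounds are considered here, and "the series" means these few. Any claim that something is new, unique, unknown or untested is made for them only; others in the source may bear on it.

Measured so far in an ADME assay on liver (Mus musculus, strain BALB/c) for metabolic stability, read by HPLC, using microsomes, with a stated time of 40 min, tested at 2 uM; a higher number here means that the compound lasts longer, a lower number that the compound disappears faster:
- compound 1 `Cc1cccc(-c2cccc(NC(=O)c3nnc(CCC(=O)O)s3)c2)c1` gives 1.29 h
- compound 2 `O=C(O)CCc1ccc(OCc2nnc(C(=O)Nc3ccccc3F)s2)cc1` gives 0.115 h

Of these two numbers, compound 2 has the lower, and the gap to compound 1 lies beyond the scatter. The two compounds differ in more than one place, so their gap says little about any single change.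

Compound 3 `O=C(O)CCc1ccc(OCc2nnc(C(=O)Nc3cccc(Cl)c3)s2)cc1` is the next to be measured. It differs from compound 2 in one place: 3-chlorophenyl in place of 2-fluorophenyl on an amide-type nitrogen. In words, 3-chlorophenyl stands in place of 2-fluorophenyl on an amide-type nitrogen. Going by the values given here, no measured pair shows what this change does, so the expectation starts from compound 2 at 0.115 h. The expected result is a small rise that stays within the scatter, estimated as a 1.2-fold higher number from compound 2 to compound 3 (0.09 log units; within the scatter). For compound 3 the estimated half-life is 0.14 h, with an expected range of 0.06 h to 0.35 h.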

Compound 3, half-life in the Mus musculus assay: 0.22 h
The estimate for compound 3 lay 1.6-fold (0.20 log units) below the measured number; the range from low to high includes it.
By their numbers in the Mus musculus assay, from the lowest: compounds 2 and 3 (each within the scatter of the next); then compound 1.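

In the Mus musculus assay, 3-chlorophenyl in place of 2-fluorophenyl on an amide-type nitrogen gives a 1.9-fold higher number from compound 2 to compound 3 (0.28 log units; within the scatter). Going by these compounds alone, this is the first pair that differs in one place, and it shows that this change leaves the half-lives of the two compounds within the scatter of each other. The same pair does part in a physicochemical assay for lipophilicity, read by LC-MS, at pH 7.4 (a lower number here means a more polar compound, a higher number a more lipophilic compound), where compound 2 gives 0.95 and compound 3, the more lipophilic, gives 1.46 with a gap beyond the scatter that is not matched by one in half-life: the measured distribution coefficient of compound 2, 0.95, and of compound 3, 1.46, a number 0.51 log units higher (beyond the scatter).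

This single step swaps the halogen and its place on the phenyl ring together, and the effects of the two stay unseparated. The compounds shown also leave open how a phenyl ring with no halogen, or one carrying a methoxy group or a nitrile, would fare on this nitrogen.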